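Methyl in Place of Hydrogen on a Second Core

The compounds below may be only part of what the source reports. "The series", "measured", "known", "first", "only" and "open" are said of these compounds alone.

Of the compounds shown here, three have been measured in a functional assay on J774 cells (Mus musculus) for cytotoxicity, read by resazurin assay; a lower number here means a stronger inhibitor, a higher number a weaker inhibitor. Compound 1 `OCCCCCC(O)c1ccc(-c2ccc(F)cc2)cc1` gives 18000 nM. Compound 2 `OCCCCCC(O)c1ccc(-c2ccc(F)cc2F)cc1` gives 8000 nM, and compound 3 `Cc1cc(F)ccc1-c1ccc(C(O)CCCCCO)cc1` gives 20000 nM. The step of a 2.3-fold lower number from compound 1 to compound 2 (0.35 log units; beyond the scatter) rests on the change (fluoro in place of hydrogen on an aromatic carbon), and compound 2 stands with the lowest number of the three. The step of a 1.1-fold higher number from compound 1 to compound 3 (0.05 log units; within the scatter) rests on the change (methyl in place of hydrogen on an aromatic carbon), while the step of a 2.5-fold higher number from compound 2 to compound 3 (0.40 log units; beyond the scatter) separates the two compounds that each carry one added group.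

Compound 4 `Cc1cc(C(O)CCCCCO)ccc1-c1ccc(F)cc1F` has not yet been measured in this assay. It differs from compound 2 by methyl in place of hydrogen on an aromatic carbon. Among the compounds with values here, this is the same kind of change as the one from compound 1 to compound 3, though the surroundings differ: there the methyl sits ortho to a large group and meta to a fluoro group (1 heavy atom), whereas here it sits ortho to a group of 8 heavy atoms and meta to a group of 8 heavy atoms. The two cores differ by fluoro in place of hydrogen on an aromatic carbon.

Because a 1.1-fold higher number from compound 1 to compound 3 (0.05 log units; within the scatter) stayed within the scatter, the expected step from compound 2 to compound 4 is also small, a 1.2-fold higher number from compound 2 to compound 4 (0.07 log units; within the scatter). Within the data shown here, compound 4 is therefore estimated at 9500 nM in this assay, with a range from 4500 nM to 20000 nM expected, since only a single pair supports the transfer.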

Compound 4, half-maximal inhibitory concentration: 8000 nM
The estimate for compound 4 lay 1.2-fold (0.07 log units) above the measured number, within the range that was stated.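

In this assay, methyl in place of hydrogen on the core of compound 2 gives no change at the digits printed from compound 2 to compound 4 (within the scatter), so the added group leaves the reading where it was on this core. Set beside the earlier pair, the change carries from one core to the other with no difference beyond the scatter: the same change on two cores in this assay, a 1.1-fold higher number (0.05 log units; within the scatter) from compound 1 to compound 3 and no change at the digits printed (within the scatter) from compound 2 to compound 4, 1.1-fold (0.05 log units) apart, within the scatter of two such steps This agreement rests on only two pairs, on two cores that differ by one fluoro group, and with the methyl in different surroundings in each pair, so it shows that the change was tolerated in these two cases, not that it would be on other cores or at other places on the rings, and it gives no reason for the result.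

The compounds shown leave open whether a larger or different group in the same place, such as an ethyl, a methoxy, a chloro or an amine, would also leave the number unchanged. They also leave open whether the methyl step would stay as small if the hydroxyl-bearing chain were replaced by a longer chain or ended in a carboxylic acid.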